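This account rests on a few compounds, and the source may have more. Where it says the series, first, only, none or still open, it means among the compounds named here.

Of the compounds shown here, three have been measured in a functional assay on IMR-32 cells for inhibition of Voltage-dependent N-type calcium channel subunit alpha-1B (Homo sapiens), read by calcium flux; a lower number here means a stronger inhibitor, a higher number a weaker inhibitor. Compound 1, `COc1ccc(CNC(=O)[C@H](CSCC2CCCCC2)NC(=O)OC(C)(C)C)cc1`, gives 610 nM in this assay. Compound 2, `COc1ccc(CNC(=O)[C@H](CSCC2CCCC2)NC(=O)OC(C)(C)C)cc1`, gives 630 nM. For the measured compounds named here, the one step recorded between them, a 1.0-fold higher number from compound 1 to compound 2 (0.01 log units; within the scatter), swaps a cyclopentyl for a cyclohexyl on a saturated chain carbon bound to a sulfur and lies within the scatter. Compound 3, `COc1ccc(COC(=O)[C@@H](CC(=O)OC2CCCC2)NC(=O)OC(C)(C)C)cc1`, gives 2000 nM in this assay, the highest of the three numbers; its nearest neighbour is compound 2, and its furthest is compound 1, both beyond the scatter.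

The piece turns to compound 4, `COc1ccc(COC(=O)[C@H](CC(=O)OC2CCCC2)NC(=O)OC(C)(C)C)cc1`, which has not yet been measured. Relative to compound 3 it shows (the two compounds have the same atoms and bonds and differ only in configuration as drawn: 1 of 1 stereo elements differ; a stereocentre at a saturated chain carbon is drawn R in compound 3 and S in compound 4). Going by the values given here, no measured step bears on such a change: the only recorded step, a 1.0-fold higher number from compound 1 to compound 2 (0.01 log units; within the scatter), concerns a ring swap and not a configuration, and it was within the scatter. With nothing in the data to guide the direction of an inversion at the stereocentre, the expectation is cautious. For compound 4 the expected step in this assay is a 1.1-fold higher number from compound 3 to compound 4 (0.04 log units; within the scatter), with no clear direction. Compound 4 is therefore estimated at 2200 nM, with a range from 700 nM to 7000 nM.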

Compound 4, half-maximal inhibitory concentration: 3400 nM
Compound 4: middle estimate off by 1.5-fold (0.19 log units), on the low side; the measured number falls inside the stated range.
By their numbers in this assay, from the lowest: compounds 1 and 2 (each within the scatter of the next); then compounds 3 and 4 (each within the scatter of the next).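

In this assay, inverting the stereocentre at the saturated chain carbon, drawn R and then S, gives a 1.7-fold higher number from compound 3 to compound 4 (0.23 log units; within the scatter). For the compounds shown here, this is the first reading on configuration, something the cyclopentyl for cyclohexyl swap could not supply, and it shows that the drawn configuration at this position does not clearly separate the two compounds, so neither form can be called the stronger inhibitor. The comparison is a clean one, with this stereocentre as the sole point of difference: the fact that compounds 3 and 4 differ only in the configuration as drawn.

The compounds shown leave open whether the same inversion would also stay within the scatter in the series of compound 1 and compound 2, which carries a sulfur-linked ring and an amide rather than the two esters, since no pair of opposite configuration is shown there. They also leave open how the number would respond if a carboxylic acid or a primary amine stood in place of the cyclopentyl ester, and whether either configuration would then read differently from the other.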